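From isobutoxy to benzyloxy: a step past three limits

A few compounds are considered here, and "the series" means these few. Any claim that something is new, unique, unknown or untested is made for them only; others in the source may bear on it.

Compound 1 `CCOC(=O)c1c(-c2cccc(OC)c2)[nH]c2cc(OC)ccc2c1=O`: > 21500 nM
Compound 2 `CCOC(=O)c1c(-c2cccc(OCC)c2)[nH]c2cc(OC)ccc2c1=O`: > 21500 nM
Compound 3 `CCOC(=O)c1c(-c2cccc(OCC(C)C)c2)[nH]c2cc(OC)ccc2c1=O`: > 21500 nM

The three compounds were measured in an ADME assay on Raji cells (Homo sapiens) for cytotoxicity, read by luminescence, with a stated time of 72 h; on this read-out lower numbers stand for an effect already at smaller amounts and higher numbers for an effect only at larger amounts of compound. Compound 3 gives > 21500 nM, which is a limit of the assay and not a number. Compound 3 therefore stands with the other two compounds, and the shared position is the limit of > 21500 nM in this assay, at which 3 of the 3 values shown sit.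

Compound 4 `CCOC(=O)c1c(-c2cccc(OCc3ccccc3)c2)[nH]c2cc(OC)ccc2c1=O` has not yet been measured. It carries phenyl in place of isopropyl on a saturated chain carbon bound to an oxygen on an aromatic ring, so that isobutoxy gives way to benzyloxy: phenyl in place of isopropyl on a saturated chain carbon bound to an oxygen on an aromatic ring.

Three measured steps change the same chain. The closest to the new change is a step that the two limits leave unreadable from compound 2 to compound 3. The other two are a step that the two limits leave unreadable from compound 1 to compound 2 and a step that the two limits leave unreadable from compound 1 to compound 3. None of them has a size that can be carried over to compound 4, and none shows a direction. No step beyond the scatter is therefore expected in this assay, and compound 4 is expected to be reported as a limit as well. The expected step is a number no higher from compound 3 to compound 4 (the limit leaves the size open). The estimate for compound 4 is 21500 nM, with an expected range from 10000 nM to 40000 nM.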

Compound 4, half-maximal effective concentration: > 21500 nM
Compound 4 gave a limit, no number; the forecaster's own chance of this, stated with the estimate: 80%; the middle value sits exactly at the limit.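

In this assay compound 4 gives > 21500 nM, which is a limit of the assay and not a number. No step between compound 4 and compound 1, compound 2 or compound 3 can therefore be read, and all four share one position: the limit of > 21500 nM in this assay, at which 4 of the 4 values shown sit.

The compounds shown leave open whether these chains differ at all in this assay.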